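Acetamido for hydroxy on a thiocarbamate aryl ether

A few compounds are considered here, and "the series" means these few. Any claim that something is new, unique, unknown or untested is made for them only; others in the source may bear on it.

The measured compounds, in a physicochemical assay for lipophilicity; a higher number here means a more lipophilic compound, a lower number a more polar compound:
Compound 1, `CC(=O)Nc1ccc(OC(=S)Nc2ccc(Nc3ccc([N+](=O)[O-])cc3)cc2)cc1`, gives 4.32.
Compound 2, `CC(=O)Nc1ccc(OC(=S)Nc2ccc(Sc3ccc(C(F)(F)F)cc3)cc2)cc1`, gives 5.96.
Compound 3, `O=[N+]([O-])c1ccc(Sc2ccc(NC(=S)Oc3ccc(O)cc3)cc2)cc1`, gives 5.25.

Among these three numbers, compound 3 stands second highest in this assay. Its nearest neighbour is compound 2, which lies above it by more than the scatter of repeated measurements; compound 1 lies furthest from it, below it, again by more than the scatter. Among the measured compounds shown here, no two of the measured compounds differ in only one place, so no single step between them can be read off, and the three values can only be set side by side.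

Compound 4, `CC(=O)Nc1ccc(OC(=S)Nc2ccc(Sc3ccc([N+](=O)[O-])cc3)cc2)cc1`, has not yet been measured in this assay. It differs from compound 3 in one place: acetamido in place of hydroxy on an aromatic carbon.

An exchange of hydroxy for acetamido at an aromatic carbon is expected to move this assay only a little downward, close to the scatter but slightly beyond it, a step estimated as a number 0.25 log units lower from compound 3 to compound 4 (within the scatter). On that basis compound 4 is expected to give about 5 in this assay, with a likely range from 4.5 to 5.5.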

Compound 4, partition coefficient: 5.06
Compound 4: middle estimate off by 0.06 log units, on the low side; the range from low to high includes it.
By their numbers in this assay, from the lowest: compound 1; then compounds 4 and 3 (each within the scatter of the next); then compound 2.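

In this assay, among the compounds shown here, the exchange of 4-hydroxyphenyl to 4-acetamidophenyl, para to a large group, gives the first direct reading at this position: the step is a number 0.19 log units lower from compound 3 to compound 4 (within the scatter) and so cannot be told from repeat measurement, which means that hydroxy and acetamido here give values that this assay does not separate, even though the heavy atom count of the group rises from 1 to 4. The other two single changes do register, as nitro in place of trifluoromethyl on an aromatic carbon gives a number 0.90 log units lower from compound 2 to compound 4 (beyond the scatter) and (4-nitrophenyl)sulfanyl in place of (4-nitrophenyl)amino gives a number 0.74 log units higher from compound 1 to compound 4 (beyond the scatter) in the same assay, so compound 4 now links all three earlier compounds and the spread among them lies in the changes away from this position. Nothing among the data shown explains the size of any of these steps.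

As far as these compounds go, the exchange at this position is read on one background only, so whether it stays as small with the trifluoromethyl or the amino-linked partners remains open. Also open, from the compounds shown here alone, is how this position would read with an amine, a carboxylic acid or a longer acyl chain in place of hydroxy and acetamido.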